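Aryl swap on the double-bonded ring carbon of compound 1

A few compounds are considered here, and "the series" means these few. Any claim that something is new, unique, unknown or untested is made for them only; others in the source may bear on it.

Measured so far:
compound 1 `COc1ccc(C2=C(c3ccc(SC)cc3)CC3CCCN3C2=O)cc1C`, 90 nM
compound 2 `COc1ccc(C2=C(c3ccc(SC)cc3)CC3CCCN3C2=O)cc1`, 2000 nM

In a functional assay on U-251 cells (Homo sapiens) for cytotoxicity (a higher number here means a weaker inhibitor of growth, a lower number a stronger inhibitor of growth), compound 1 gives 90 nM, the lowest of the two numbers. Within the data shown here, the only other measured compound is compound 2 with 2000 nM, and the step of a 22-fold higher number from compound 1 to compound 2 (1.35 log units; beyond the scatter) is large.

Compound 3 `CSc1ccc(C2=C(c3ccc(F)cc3)C(=O)N3CCCC3C2)cc1` is not yet measured. It differs from compound 1 by 4-fluorophenyl in place of 4-methoxy-3-methylphenyl on a double-bonded ring carbon. Among the measured compounds shown here, the one measured step that bears on this, a 22-fold higher number from compound 1 to compound 2 (1.35 log units; beyond the scatter), already covers the loss of the methyl on the aromatic carbon; compound 3 loses that methyl and the methoxy as well, and gains a fluorine. For the measured compounds named here, no measured step speaks to the methoxy or the fluorine. The expectation for compound 3 in this assay is therefore a higher number, at least of the size seen in a 22-fold higher number from compound 1 to compound 2 (1.35 log units; beyond the scatter), with wide uncertainty for the extra change: the expected step is a 56-fold higher number from compound 1 to compound 3 (1.74 log units; beyond the scatter). Compound 3 is estimated at 5000 nM, within 1000 nM to 25000 nM.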

Compound 3, concentration for 50% growth inhibition: 90 nM
The estimate for compound 3 lay 56-fold (1.74 log units) above the measured number; measured number outside the range, below it.
By their numbers in this assay, from the lowest: compounds 1 and 3 (each within the scatter of the next); then compound 2.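

At the double-bonded ring carbon, the 4-methoxy-3-methylphenyl group of compound 1 can give way to 4-fluorophenyl in this assay, with no change at the digits printed from compound 1 to compound 3 (within the scatter), so the methyl is not required on every aryl group at this position. Among these compounds, with no methyl on either compound, fluoro in place of methoxy on the aromatic carbon gives a 22-fold lower number from compound 2 to compound 3 (1.35 log units; beyond the scatter); the aryl group of compound 2 is the only one of the three that stands apart from the others. No measurement on hand accounts for this difference.

As far as these compounds go, whether adding a methyl to the 4-fluorophenyl group of compound 3 would change the number remains open, as does the outcome of a chlorine, an amine or a carboxylic acid in place of the fluorine. The 4-(methylsulfanyl)phenyl group is the same in all three compounds, so its contribution cannot be read.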